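The source may report more compounds than this note shows. Statements on the series, on what has been measured and on what is new or still open speak of the compounds shown alone.

Measured compounds:
compound 1, `CCn1c(C(=O)N[C@H](C)CO)ccc1C(CC)(CC)c1ccc(OCS(=O)(=O)c2ccccc2)c(C)c1`, 7790 nM in a functional assay on PC-3 cells (Homo sapiens) for antiproliferative activity, read by MTT assay, with a stated time of 24 h; on this read-out higher numbers stand for weaker inhibition and lower numbers for stronger inhibition
compound 2, `CCn1c(C(=O)N[C@@H](CO)C(C)C)ccc1C(CC)(CC)c1ccc(OCS(=O)(=O)c2ccccc2)c(C)c1`, 10600 nM
compound 3, `CCn1c(C(=O)N[C@@H](C(=O)O)C(C)C)ccc1C(CC)(CC)c1ccc(OCS(=O)(=O)c2ccccc2)c(C)c1`, 3070 nM

Compound 1 stands second highest of the three numbers. Its nearest neighbour is compound 2, a 1.4-fold higher number from compound 1 to compound 2 (0.13 log units; within the scatter); its furthest is compound 3, a 2.5-fold lower number from compound 1 to compound 3 (0.40 log units; beyond the scatter). Compound 2 and compound 3 differ in one place as well, a 3.5-fold lower number from compound 2 to compound 3 (0.54 log units; beyond the scatter).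

The step from compound 1 to compound 4, `CCn1c(C(=O)N[C@H](CC(=O)O)C(=O)O)ccc1C(CC)(CC)c1ccc(OCS(=O)(=O)c2ccccc2)c(C)c1`, changes the amide side chain: 1,2-dicarboxyethyl in place of 1-(hydroxymethyl)ethyl on an amide-type nitrogen. The measured steps that bear on this are those toward compound 3, where a carboxy group enters in place of a hydroxymethyl group and the number falls beyond the scatter in both comparisons. Among the measured compounds shown here, compound 4 carries two carboxy groups, so the direction is expected to be the same, toward a lower number, and of modest size; a second carboxy group has no measured precedent here, which widens the range. Compound 4 is therefore expected to give 4500 nM, between 1800 nM and 11000 nM, that is a 1.7-fold lower number from compound 1 to compound 4 (0.24 log units; within the scatter).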

Compound 4, half-maximal inhibitory concentration: > 50000 nM
Compound 4: no number, only a limit (the forecaster's own chance of this, stated with the estimate: 5%); middle value at least 11-fold (1.04 log units) from the limit.
By their numbers in this assay, from the lowest: compound 3; then compounds 1 and 2 (each within the scatter of the next). At a limit, above all of these: compound 4.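

Compound 4 gives no number in this assay, only a limit: the limit of > 50000 nM in this assay, at which 1 of the 4 values shown sits.

The steps to it all run upward and beyond the scatter, with an at least 6.4-fold higher number from compound 1 to compound 4 (0.80 log units; beyond the scatter) and an at least 4.7-fold higher number from compound 2 to compound 4 (0.67 log units; beyond the scatter); with an at least 16-fold higher number from compound 3 to compound 4 (1.21 log units; beyond the scatter), carboxymethyl stands in place of isopropyl on the saturated chain carbon. The earlier compounds shown here showed a single carboxy group on this amide side chain going with a lower number, and compound 4 shows that the 1,2-dicarboxyethyl group on the amide-type nitrogen reverses that direction.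

The compounds shown leave open whether this reversal follows from the second carboxylic acid itself or from the loss of the isopropyl group. An amide or an amine in place of that second carboxylic acid, or a longer chain carrying it, would separate the two.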